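Trifluoromethyl added to the aryl amide of compound 1

This account rests on a few compounds, and the source may have more. Where it says the series, first, only, none or still open, it means among the compounds named here.

Compounds measured so far in a functional assay on UACC-62 cells (Homo sapiens) for inhibition, read by sulforhodamine B assay, with a stated time of 48 h; on this read-out higher numbers stand for lower toxicity in this test and lower numbers for higher toxicity in this test:
compound 1 `O=C(Nc1cccc(-n2cc(-c3ccncc3)c(-c3ccc(Cl)c(O)c3)n2)c1)Nc1cccc(C(F)(F)F)c1`: 21900 nM
compound 2 `O=C(Nc1cccc(-n2cc(-c3ccncc3)c(-c3ccc(Cl)c(O)c3)n2)c1)Nc1ccc(Cl)c(Cl)c1`: 29200 nM
compound 3 `COc1cc(-c2nn(-c3cccc(NC(=O)c4ccc(Cl)c(C(F)(F)F)c4)c3)cc2-c2ccncc2)ccc1Cl`: a limit only, > 32500 nM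

Compound 1 stands at the lowest of the two numbers in this assay; its nearest neighbour is compound 2, and the step of a 1.3-fold higher number from compound 1 to compound 2 (0.12 log units; within the scatter) is within the scatter. Compound 3 gives no number in this assay, only a limit, at the limit of > 32500 nM in this assay, at which 1 of the 3 values shown sits.

Compound 4 `O=C(Nc1cccc(-n2cc(-c3ccncc3)c(-c3ccc(Cl)c(O)c3)n2)c1)Nc1cc(C(F)(F)F)cc(C(F)(F)F)c1` is the next step from compound 1: trifluoromethyl in place of hydrogen on an aromatic carbon. Among the measured compounds shown here, the only measured step on this ring, a 1.3-fold higher number from compound 1 to compound 2 (0.12 log units; within the scatter), exchanged the whole aryl group and stayed within the scatter. No step beyond the scatter is therefore expected for compound 4 in this assay, and the estimated step is a 1.1-fold higher number from compound 1 to compound 4 (0.06 log units; within the scatter). Compound 4 is expected to give about 25000 nM, between 11000 nM and 50000 nM. The nearby limit of > 32500 nM in this assay, at which 1 of the 3 values shown sits, means a limit-only reading is a real possibility for compound 4.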

Compound 4, concentration lethal to 50% of the cells: 8460 nM
Estimate against measurement, compound 4: 3.0-fold (0.47 log units) above, outside the stated range (below it).
By their numbers in this assay, from the lowest: compound 4; then compounds 1 and 2 (each within the scatter of the next). At a limit, above all of these: compound 3.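

In this assay, among the compounds shown here, a trifluoromethyl in place of hydrogen on this aromatic carbon gives the first step on this ring that lies beyond the scatter (a 2.6-fold lower number from compound 1 to compound 4 (0.41 log units; beyond the scatter)). The earlier exchange of the whole aryl group stayed within the scatter (a 1.3-fold higher number from compound 1 to compound 2 (0.12 log units; within the scatter)), so this ring is not indifferent to substitution: a single added group here moves the number towards higher toxicity in this test. Nothing shown gives a cause for this step.

Going by these compounds, whether the step belongs to trifluoromethyl itself or would also follow from another group at this place, such as an amine or a carboxylic acid, stays open. Compound 3 gives only a limit (> 32500 nM), so how its series responds to changes on this ring cannot be read.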